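The source may hold more compounds than are shown below. What is called first, only, known or untested is meant among the compounds shown, and "the series" means these compounds.

Measured compounds in this series:
compound 1 `CN(C)c1ccc(C(=O)CCCCOc2ccc(S(=O)(=O)C3(C(=O)NO)CCOCC3)cc2)cc1` — 1100 nM
compound 2 `CN(C)c1ccc(C(=O)CCCOc2ccc(S(=O)(=O)C3(C(=O)NO)CCOCC3)cc2)cc1` — 930 nM
compound 3 `CN(C)c1ccc(NC(=O)CCCOc2ccc(S(=O)(=O)C3(C(=O)NO)CCOCC3)cc2)cc1` — 960 nM

In an assay on isolated protein for inhibition of matrix metalloproteinase-9 (Homo sapiens) (a lower number here means a stronger inhibitor, a higher number a weaker inhibitor), compound 3 gives 960 nM, the second highest of the three numbers; compound 2 and compound 1 sit within the scatter of it on either side, so the three are indistinguishable. Within the data shown here, the only single-point step among the measured compounds, a 1.0-fold higher number from compound 2 to compound 3 (0.01 log units; within the scatter), concerns the group on the carbonyl carbon and leaves the aromatic substituent untouched.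

Compound 4 `O=C(CCCOc1ccc(S(=O)(=O)C2(C(=O)NO)CCOCC2)cc1)Nc1ccc(OC(F)(F)F)cc1` differs from compound 3 by trifluoromethoxy in place of dimethylamino on an aromatic carbon. Among the measured compounds shown here, no measured step bears on this change: the dimethylamino group is present in every measured compound, and nothing shows what a different substituent on that ring does in this assay. For the measured compounds named here, with no step to lean on, the expectation is that the step of a 1.1-fold lower number from compound 3 to compound 4 (0.03 log units; within the scatter) stays within the scatter, and the range is kept wide to allow for an unobserved change in either direction. Compound 4 is therefore estimated at 900 nM, between 350 nM and 2500 nM.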

Compound 4, half-maximal inhibitory concentration: 180 nM
Compound 4: middle estimate off by 5.0-fold (0.70 log units), on the high side; the measured number lies below the stated range.
By their numbers in this assay, from the lowest: compound 4; then compounds 2, 3 and 1 (each within the scatter of the next).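

In this assay the aromatic substituent proves to be a position that responds: trifluoromethoxy in place of dimethylamino, para to a large group, gives a 5.3-fold lower number from compound 3 to compound 4 (0.73 log units; beyond the scatter) and so contrasts with the change on the carbonyl carbon, a 1.0-fold higher number from compound 2 to compound 3 (0.01 log units; within the scatter) which stays within the scatter. Measured against the other neighbour, (4-(trifluoromethoxy)phenyl)amino in place of 4-(dimethylamino)phenyl on a carbonyl carbon gives a 5.2-fold lower number from compound 2 to compound 4 (0.71 log units; beyond the scatter) and so points the same way. No supporting measurement accounts for this shift, and the data do not separate the departure of dimethylamino from the arrival of trifluoromethoxy.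

Open, going by these compounds, is whether chlorine, methoxy, trifluoromethyl or a plain hydrogen at this position would follow compound 4 or compound 3. Also open, on these data alone, is whether trifluoromethoxy gives a similar step on the longer chain of compound 1.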